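Exchanging the aromatic ether group in compound 2

This account rests on a few compounds, and the source may have more. Where it says the series, first, only, none or still open, it means among the compounds named here.

Going by the values given here, compound 2 `Cc1cc(C(=O)O)ccc1CN1CCC[C@H](O[C@H](CF)c2cc(Cl)cc(Cl)c2)[C@@H]1c1ccccc1` gives the lowest of the two numbers known so far in an assay on isolated protein for activation of cGMP-dependent protein kinase 1 (Homo sapiens), read by ADP-Glo, with stated times of 30 min and 2 h, in the presence of a further agent that is not named here (a lower number here means that less compound is needed, a higher number that more compound is needed for the effect), namely 9100 nM. Among the compounds with values here, its only measured neighbour is compound 1 `COc1cccc([C@@H](CO)O[C@H]2CCCN(Cc3ccc(C(=O)O)cc3C)[C@H]2c2ccccc2)c1`, which in this assay gives 81000 nM, and the two are separated by the step of an 8.9-fold lower number from compound 1 to compound 2 (0.95 log units; beyond the scatter). Compound 3 `Cc1cc(C(=O)O)ccc1CN1CCC[C@H](O[C@H](CO)c2ccnc(Cl)c2)[C@@H]1c1ccccc1` has not been measured. It differs from compound 2 by a group of 10 heavy atoms (7 carbon, 1 nitrogen, 1 oxygen, 1 chlorine; one six-membered aromatic ring with 1 hetero atom) in place of a group of 11 heavy atoms (8 carbon, 1 fluorine, 2 chlorine; one six-membered aromatic ring of carbon only), on an oxygen on a saturated carbon. Within the data shown here, the single measured step, an 8.9-fold lower number from compound 1 to compound 2 (0.95 log units; beyond the scatter), bears on this change only in part: there, one carbon-only aromatic group carrying oxygen gave way to another carrying chlorine and fluorine, whereas the change to compound 3 brings oxygen and a donor back while keeping chlorine and introducing a ring with a hetero atom. Compound 3 thus shares features with both measured compounds, and its number is expected to fall between the two, so the expected step of a 3.3-fold higher number from compound 2 to compound 3 (0.52 log units; beyond the scatter) goes toward a higher number. Compound 3 is accordingly estimated at 30000 nM, with a range from 8000 nM to 100000 nM.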

Compound 3, half-maximal effective concentration: 50000 nM
The estimate for compound 3 lay 1.7-fold (0.22 log units) below the measured number, and the stated range covers the measured number.
By their numbers in this assay, from the lowest: compound 2; then compounds 3 and 1 (each within the scatter of the next).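

The change from compound 2 to compound 3 (a 5.5-fold higher number from compound 2 to compound 3 (0.74 log units; beyond the scatter)) shows that in this assay, replacing the group with fluorine and two chlorines on an oxygen on a saturated carbon gives up much of the gain seen earlier, so compound 2 remains the only one of the three set apart beyond the scatter from both others. The new pair, a 1.6-fold lower number from compound 1 to compound 3 (0.21 log units; within the scatter), adds a cleaner comparison: with 2-chloropyridin-4-yl in place of 3-methoxyphenyl, a change confined to the aromatic ring, the two numbers cannot be told apart, so a ring with a hetero atom and a chlorine does not by itself reproduce the lower number of compound 2. No measurement is available that would explain these differences.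

The compounds shown leave open whether the lower number of compound 2 rests on its fluorine-bearing chain, on its chlorine-bearing carbon-only ring, or on the two together, since the step to compound 3 changes both at once. They also leave open how this place would respond to a chain ending in an amine or a carboxylic acid, or to a longer chain.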